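Nitrophenyl-to-fluorophenyl sulfonyl swap on a second core

This account rests on a few compounds, and the source may have more. Where it says the series, first, only, none or still open, it means among the compounds named here.

The series is built around an acrylamide carrying a nitrile, linked through an amide to a thiadiazole that bears a benzyl group. Compound 1 `COc1ccc(Cc2nnc(NC(=O)/C(C#N)=C/c3ccccc3OS(=O)(=O)c3ccccc3[N+](=O)[O-])s2)cc1` carries a 4-methoxybenzyl group on the thiadiazole and a (2-nitrophenyl)sulfonyl ester on the aryl ring of the acrylamide. In a functional assay on HL-60 cells (Homo sapiens) for inhibition, read by CCK-8 assay, with a stated time of 48 h, tested at 20 uM (on this read-out lower numbers stand for less inhibition of growth and higher numbers for more inhibition of growth at the one concentration tested), compound 1 gives 25%. Compound 2 `COc1ccc(Cc2nnc(NC(=O)/C(C#N)=C/c3ccccc3OS(=O)(=O)c3ccc(F)cc3)s2)cc1` differs from compound 1 by 4-fluorophenyl in place of 2-nitrophenyl on a sulfonyl sulfur; in this assay compound 2 gives 25%, and the step is no change at the digits printed from compound 1 to compound 2 (within the scatter). Compound 3 `N#C/C(=C\c1ccccc1OS(=O)(=O)c1ccccc1[N+](=O)[O-])C(=O)Nc1nnc(Cc2cccc(F)c2)s1` differs from compound 1 in the core by 3-fluorophenyl in place of 4-methoxyphenyl on a saturated chain carbon bound to an aromatic carbon; in this assay compound 3 gives 23%, and the step is a number 2 percentage points lower from compound 1 to compound 3 (within the scatter). All three measured values lie within the scatter of one another, so no ranking among them is supported.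

Compound 4 `N#C/C(=C\c1ccccc1OS(=O)(=O)c1ccc(F)cc1)C(=O)Nc1nnc(Cc2cccc(F)c2)s1` is not yet measured. Relative to compound 3 it carries 4-fluorophenyl in place of 2-nitrophenyl on a sulfonyl sulfur. This is the same change as that from compound 1 to compound 2: the place is described in identical words in both pairs, and only the core differs, by 3-fluorophenyl in place of 4-methoxyphenyl on a saturated chain carbon bound to an aromatic carbon as given above. Going by the values given here, the one precedent for this change, from compound 1 to compound 2, produced no change at the digits printed from compound 1 to compound 2 (within the scatter).

On that basis the expected step for compound 4 in this assay is a number 1 percentage points higher from compound 3 to compound 4 (within the scatter), again within the scatter. Among the compounds with values here, the estimate for compound 4 in this assay is 24%, with a range from 14% to 34%, because the only matching step no change at the digits printed from compound 1 to compound 2 (within the scatter) showed no movement.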

Compound 4, percent growth inhibition at one concentration: 22%
For compound 4 the middle estimate is 2 percentage points above the measured one, and the stated range covers the measured number.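

In this assay, 4-fluorophenyl in place of 2-nitrophenyl on a sulfonyl sulfur gives a number 1 percentage points lower from compound 3 to compound 4 (within the scatter), and the step reads the same on the core of compound 3 as on the core of compound 1: the same change on two cores in this assay, no change at the digits printed (within the scatter) from compound 1 to compound 2 and a number 1 percentage points lower (within the scatter) from compound 3 to compound 4, 1 percentage points apart, within the scatter of two such steps

The second change, 3-fluorophenyl in place of 4-methoxyphenyl on a saturated chain carbon bound to an aromatic carbon, gives a number 3 percentage points lower from compound 2 to compound 4 (within the scatter), and it too reads the same with either sulfonyl group: the same change on two cores in this assay, a number 2 percentage points lower (within the scatter) from compound 1 to compound 3 and a number 3 percentage points lower (within the scatter) from compound 2 to compound 4, 1 percentage points apart, within the scatter of two such steps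

Going by these compounds alone, every step in this square lies within the scatter, so the agreement shows only that neither change is resolved by this read-out on these compounds; it does not show that a step of real size would carry from one core to another, and it says nothing beyond the one concentration tested.

On these data alone, open questions: it remains open whether an aminophenyl or a carboxyphenyl on the sulfonyl sulfur would give a step beyond the scatter, and whether such a step would hold on both cores. The same question stands for a longer chain in place of the single saturated carbon that carries the aryl ring on the thiadiazole.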